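Swapping Phenyl for Pyridin-2-yl on a Benzyl Arm

The source may hold more compounds than are shown below. What is called first, only, known or untested is meant among the compounds shown, and "the series" means these compounds.

Of the compounds shown here, three built on a shared core have been tested in an assay on isolated protein for inhibition of protein deacetylase HDAC6 (Homo sapiens), read by mobility shift assay; on this read-out lower numbers stand for stronger inhibition and higher numbers for weaker inhibition. Compound 1 `O=C(NO)c1ccc(CN(Cc2ccccc2)S(=O)(=O)c2c(F)c(F)c(F)c(F)c2F)cc1` gives 9 nM. Compound 2 `Cc1ccc(CN(Cc2ccc(C(=O)NO)cc2)S(=O)(=O)c2c(F)c(F)c(F)c(F)c2F)cc1`, which carries a methyl in place of hydrogen on an aromatic carbon, gives 6 nM. Compound 3 `O=C(NO)c1ccc(CN(Cc2ccccc2)S(=O)(=O)c2cc(F)c(F)c(F)c2F)cc1` gives 5 nM, the lowest of the three numbers, although its gaps to compound 2 and compound 1 both stay within the scatter. The two single-point changes measured so far are small: a 1.5-fold lower number from compound 1 to compound 2 (0.18 log units; within the scatter) and a 1.8-fold lower number from compound 1 to compound 3 (0.26 log units; within the scatter).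

Compound 4 `O=C(NO)c1ccc(CN(Cc2ccccn2)S(=O)(=O)c2cc(F)c(F)c(F)c2F)cc1` has not yet been measured. It differs from compound 3 in one place: pyridin-2-yl in place of phenyl on a saturated chain carbon bound to a sulfonamide nitrogen. For the measured compounds named here, no measured step exchanges a carbon-only ring for a ring with one hetero atom, so nothing among the three compounds speaks directly to this change. What has been measured, a methyl added and a fluoro removed, each left the number within the scatter, and these results give no reason to expect a larger shift here. Compound 4 is therefore expected to land close to compound 3, with an estimated step of a 1.2-fold higher number from compound 3 to compound 4 (0.08 log units; within the scatter) in this assay. The estimate for compound 4 is 6 nM, with an expected range from 2.5 nM to 15 nM.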

Compound 4, half-maximal inhibitory concentration: 6 nM
The estimate for compound 4 equals the measured number at the digits printed; the measured number falls inside the stated range.
By their numbers in this assay, from the lowest: compounds 3, 2, 4 and 1 (each within the scatter of the next).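

In this assay the exchange of phenyl for pyridin-2-yl on a saturated chain carbon bound to a sulfonamide nitrogen gives a 1.2-fold higher number from compound 3 to compound 4 (0.08 log units; within the scatter) and so stays within the scatter. For the compounds shown here, this is the first measured step that replaces a carbon-only ring with a ring holding a hetero atom, and it shows that this arm of compound 3 can take a ring nitrogen, with the one hydrogen-bond acceptor counted for it, with no difference that can be told from the scatter. No measurement at hand explains why this step is so small.

The compounds shown leave open whether the place of the nitrogen in the ring matters, which pyridin-3-yl and pyridin-4-yl arms would test, and whether a ring with a second nitrogen, such as pyrimidin-2-yl, would fit the same pattern. They also leave open how far this arm can move away from an aromatic ring altogether, for example to a cyclohexyl ring or to a longer chain ending in an amine or a carboxylic acid.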